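Methyl on the ring nitrogen of compound 1

The compounds below may be only part of what the source reports. "The series", "measured", "known", "first", "only" and "open" are said of these compounds alone.

In an ADME assay on microsomes from liver (Rattus norvegicus) for metabolic stability (a higher number here means that the compound lasts longer, a lower number that the compound disappears faster), compound 1 (`CC(C)C(c1ccc(-c2ccc3cccc(F)c3c2)[nH]c1=O)C1NC(=O)NC1=O`) gives 0.145 h, the lower of the two numbers available. Compound 2 (`CC(C)[C@H](C[C@H]1OC(=O)NC1=O)c1ccc(-c2ccc3cccc(F)c3c2)[nH]c1=O`) gives 0.95 h, and it differs from compound 1 in several places. Compound 3 (`CC(C)C(c1ccc(-c2ccc3cccc(F)c3c2)[nH]c1=O)C1C(=O)NC(=O)N1C`) carries methyl in place of hydrogen on an amide-type nitrogen in a ring. Among the measured compounds shown here, no measured pair isolates this change, so only a small rise is expected, perhaps not beyond the scatter, and the estimated step is a 1.7-fold higher number from compound 1 to compound 3 (0.24 log units; within the scatter). For compound 3 the estimated half-life is 0.25 h, with an expected range of 0.1 h to 0.6 h.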

Compound 3, half-life: 0.263 h
Estimate against measurement, compound 3: 1.1-fold (0.02 log units) below, within the range that was stated.
By their numbers in this assay, from the lowest: compounds 1 and 3 (each within the scatter of the next); then compound 2.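

Methyl in place of hydrogen on the amide-type nitrogen in the ring gives a 1.8-fold higher number from compound 1 to compound 3 (0.26 log units; within the scatter) in this assay and is the first step here that isolates one change. It shows that this position carries methyl with no shift that can be told from the scatter. No supporting data bear on this result.

Still open, going by these compounds, is whether ethyl or a longer chain on this nitrogen would give a step beyond the scatter. Also open, on these data alone, is what methyl would do on the other ring nitrogen.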